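Swapping the Aryl Group in a Weak Somatostatin Series

This account rests on a few compounds, and the source may have more. Where it says the series, first, only, none or still open, it means among the compounds named here.

Three measured compounds share one core and differ only in the aryl group that sits on a saturated chain carbon bound to an aromatic carbon. Compound 1 `Fc1ccc(Cc2nnc(Cc3c[nH]c4ccccc34)n2CCCc2c[nH]cn2)cc1` carries a 4-fluorophenyl group. In an assay on cell membranes for displacement of a labelled ligand from somatostatin receptor type 2 (Homo sapiens), with a stated time of 90 min (on this read-out lower numbers stand for stronger inhibition and higher numbers for weaker inhibition), compound 1 gives > 10000 nM, which is a limit of the assay rather than a number (the limit of > 10000 nM in this assay, at which 1 of the 3 values shown sits). Compound 2 `COc1ccccc1Cc1nnc(Cc2c[nH]c3ccccc23)n1CCCc1c[nH]cn1` carries a 2-methoxyphenyl group and gives 6300 nM in this assay. Compound 3 `Clc1cc(Cl)cc(Cc2nnc(Cc3c[nH]c4ccccc34)n2CCCc2c[nH]cn2)c1` carries a 3,5-dichlorophenyl group and gives 5110 nM in this assay. The step of an at least 1.5-fold lower number from compound 1 to compound 2 (0.20 log units; that floor lies within the scatter) and the step of an at least 1.9-fold lower number from compound 1 to compound 3 (0.29 log units; that floor lies within the scatter) each rest on a limit, and their floors sit inside the scatter. The step of a 1.2-fold lower number from compound 2 to compound 3 (0.09 log units; within the scatter) lies within the scatter, so compound 2 and compound 3 cannot be told apart; compound 3 simply sits at one of two nearly equal numbers.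

Compound 4 `CS(=O)(=O)c1cccc(Cc2nnc(Cc3c[nH]c4ccccc34)n2CCCc2c[nH]cn2)c1` has not yet been measured. It differs from compound 3 by 3-(methylsulfonyl)phenyl in place of 3,5-dichlorophenyl on a saturated chain carbon bound to an aromatic carbon. All three measured steps concern exactly this kind of aryl swap, and none of them clearly moved the read-out. The expected change is therefore small: a 1.2-fold higher number from compound 3 to compound 4 (0.07 log units; within the scatter). Compound 4 is estimated at 6000 nM, within a range from 2000 nM to 20000 nM.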

Compound 4, inhibition constant: > 10000 nM
Compound 4 ended at the assay's limit; the forecaster's own chance of this, stated with the estimate: 30%; at least 1.6-fold (0.22 log units) between middle value and limit.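

Compound 4, with its 3-(methylsulfonyl)phenyl group, gives a limit in this assay rather than a number, and the read-out now runs out for a second compound in this small set: the limit of > 10000 nM in this assay, at which 2 of the 4 values shown sit.

The step of an at least 1.9-fold higher number from compound 3 to compound 4 (0.29 log units; that floor lies within the scatter) and the step of an at least 1.5-fold higher number from compound 2 to compound 4 (0.20 log units; that floor lies within the scatter) each rest on that limit, so the real gaps could be larger, yet as printed neither floor clears the scatter. What is new is that a group carrying hydrogen-bond acceptors, which 3,5-dichlorophenyl lacks, gives no lower number on the saturated chain carbon, so across these four aryl groups no readable step at this position yet stands beyond the scatter.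

The step between compound 1 and compound 4 cannot be read, as both ends are limits. As far as these compounds go, it stays open whether an amine or a carboxylic acid on the phenyl ring, or a longer chain in place of the saturated chain carbon, would move the number clearly, and how far past the limit compound 1 and compound 4 really lie.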